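Shortening a Long Chain on a Shared Core

A few compounds are considered here, and "the series" means these few. Any claim that something is new, unique, unknown or untested is made for them only; others in the source may bear on it.

Among the measured compounds shown here, in a functional assay on cells (Lymphocyte), read by a luciferase reporter and ATP content, with a stated time of 48 h, tested at 10 uM (on this read-out lower numbers stand for a stronger effect and higher numbers for a weaker effect at the one concentration tested), compound 2 `CCCCCCCCCCCCCCCCCCCc1nc(N(C)C)c(C)c(C)c1O` gives 102%, the highest of the two numbers measured so far, while compound 1 `Cc1c(N(C)C)nc(CCCCCCCCCCO)c(O)c1C` gives 20% in this assay. The two compounds share a core and differ only at the far end of a saturated chain: a number 82 percentage points higher from compound 1 to compound 2 (beyond the scatter). Compound 3 `CCCCCCCCCCCCCCCCc1nc(N(C)C)c(C)c(C)c1O` keeps the core of compound 2 and alters the same chain at the same distance: hydrogen in place of propyl on a saturated chain carbon, ten or more bonds along the chain from an aromatic carbon. For the measured compounds named here, the one measured step is only a partial guide, since there a hydroxy left and a nonyl entered, whereas here a propyl leaves and a hydrogen enters, with no hydroxy returning. Because the large step of a number 82 percentage points higher from compound 1 to compound 2 (beyond the scatter) combined the loss of the hydroxy with the growth of the chain, shortening the chain alone is expected to move the number by less, and if anything downward. For compound 3 the estimate in this assay is 85%, within a range from 55% to 105%, which means an expected step of a number 17 percentage points lower from compound 2 to compound 3 (beyond the scatter).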

Compound 3, a percentage reported as activity, at one concentration (the size of the read-out at that concentration, not a potency): 79%
The estimate for compound 3 lay 6 percentage points above the measured number; low and high end bracket the measured number.
By their numbers in this assay, from the lowest: compound 1; then compound 3; then compound 2.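

In this assay, the change from propyl to hydrogen gives a number 23 percentage points lower from compound 2 to compound 3 (beyond the scatter), and this is the first step shown in which a plain chain only gets shorter, with no hydroxy leaving or entering. Chain length on its own therefore moves the number at this saturated chain carbon, and in this one pair the shorter chain gives the stronger effect. The shorter chain still does not match the hydroxy-bearing compound, since hexyl in place of hydroxy gives a number 59 percentage points higher from compound 1 to compound 3 (beyond the scatter), so a large step remains between these two even after the propyl is gone.

No measurement shown here gives a reason for either step. Still open, from the compounds shown here alone, is whether trimming the plain chain further would keep lowering the number, and whether an amine or a carboxylic acid in place of the hydroxy of compound 1 would give a number as low as that compound's.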